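The source may hold more compounds than are shown below. What is called first, only, known or untested is meant among the compounds shown, and "the series" means these compounds.

Measured in a functional assay on HCT-116 cells (Homo sapiens) for cytotoxicity, read by MTT assay, with a stated time of 72 h; a higher number here means a weaker inhibitor, a lower number a stronger inhibitor:
- compound 1 `O=C1c2c[n+]([O-])c3ccccc3c2C(=O)c2c1c1ccccc1n2CCCCn1ccnc1` gives 240 nM
- compound 2 `O=C1c2c[n+]([O-])c3ccccc3c2C(=O)c2c1c1ccccc1n2Cc1cn(CC(O)CO)nn1` gives 250 nM
- compound 3 `CC1(C)O[C@@H](CO)[C@H](Cn2cc(Cn3c4c(c5ccccc53)C(=O)c3c[n+]([O-])c5ccccc5c3C4=O)nn2)O1` gives 130 nM

Compound 1 holds the second highest of the three numbers; its nearest neighbour is compound 2 and its furthest is compound 3, both within the scatter. Compound 4 `CN1CCN(CCCCCCn2c3c(c4ccccc42)C(=O)c2c[n+]([O-])c4ccccc4c2C3=O)CC1` differs from compound 1 only at the chain terminus: 2-(4-methylpiperazin-1-yl)ethyl in place of 1H-imidazol-1-yl on a saturated chain carbon, four bonds along the chain from an aromatic nitrogen. The two measured steps, a 1.0-fold higher number from compound 1 to compound 2 (0.02 log units; within the scatter) and a 1.9-fold lower number from compound 2 to compound 3 (0.28 log units; within the scatter), likewise exchange the group carried on the chain from the aromatic nitrogen and neither moves beyond the scatter. On that basis the step of a 1.0-fold lower number from compound 1 to compound 4 (0.02 log units; within the scatter) is expected to be small and without a clear direction. Compound 4 is therefore estimated at 230 nM, with a range of 110 nM to 480 nM.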

Compound 4, half-maximal inhibitory concentration: 2900 nM
Compound 4: the middle estimate sits 13-fold (1.10 log units) below what was measured, outside the stated range (above it).
By their numbers in this assay, from the lowest: compounds 3, 1 and 2 (each within the scatter of the next); then compound 4.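

The chain terminus is not indifferent to exchange in this assay: 2-(4-methylpiperazin-1-yl)ethyl in place of 1H-imidazol-1-yl gives a 12-fold higher number from compound 1 to compound 4 (1.08 log units; beyond the scatter), the first step in the series beyond the scatter. 5-(4-methylpiperazin-1-yl)pentyl in place of 1-(2,3-dihydroxypropyl)-1H-1,2,3-triazol-4-yl gives a 12-fold higher number from compound 2 to compound 4 (1.06 log units; beyond the scatter), so the loss appears against both of these compounds. Nothing available explains the loss.

As far as these compounds go, compound 4 changes the ring and the chain together, so which of the two carries the loss remains open. A morpholine on the same chain, or 4-methylpiperazin-1-yl on a shorter chain, would separate them.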